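Amine variation on the thiocarbonyl carbon of the series

This account rests on a few compounds, and the source may have more. Where it says the series, first, only, none or still open, it means among the compounds named here.

Measured so far:
compound 1 `Cc1ccc2c(=O)c(CSC(=S)N3CCCC3)coc2c1` — 41400 nM
compound 2 `Cc1ccc2c(=O)c(CSC(=S)N(C(C)C)C(C)C)coc2c1` — 6600 nM

Two numbers are in hand. In a functional assay on MCF7 cells (Homo sapiens) for antiproliferative activity, read by MTT assay, with a stated time of 72 h (on this read-out higher numbers stand for weaker inhibition and lower numbers for stronger inhibition), compound 1 gives 41400 nM, and compound 2 gives 6600 nM. Among the compounds with values here, the single step between them is a 6.3-fold lower number from compound 1 to compound 2 (0.80 log units; beyond the scatter). Compound 2 therefore stands with the lowest of the two numbers; its nearest neighbour is compound 1, and the separation lies beyond the scatter.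

Compound 3 `Cc1ccc2c(=O)c(CSC(=S)N3CCOCC3)coc2c1` has not yet been measured. Against compound 2 the change is morpholin-4-yl in place of diisopropylamino on a thiocarbonyl carbon. Within the data shown here, the only measured step that bears on this change is a 6.3-fold lower number from compound 1 to compound 2 (0.80 log units; beyond the scatter), where a cyclic amine on the thiocarbonyl carbon gave way to the open diisopropylamino and the number fell. Compound 3 goes back to a cyclic amine, now a six-membered one with an oxygen in the ring, so a partial reversal of that step is expected. Because compound 1 with its cyclic amine gave 41400 nM, the number for compound 3 is expected to rise, by an estimated 3.0-fold higher number from compound 2 to compound 3 (0.48 log units; beyond the scatter). The estimate for compound 3 is 20000 nM, with a range from 5000 nM to 60000 nM.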

Compound 3, half-maximal inhibitory concentration: 20700 nM
Compound 3: middle estimate off by 1.0-fold (0.01 log units), on the low side; the range from low to high includes it.
By their numbers in this assay, from the lowest: compound 2; then compounds 3 and 1 (each within the scatter of the next).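

In this assay, the morpholin-4-yl group separates from diisopropylamino on the thiocarbonyl carbon, with a 3.1-fold higher number from compound 2 to compound 3 (0.50 log units; beyond the scatter), so the gap seen with pyrrolidin-1-yl now appears with a second cyclic amine. Between the two cyclic amines there is a 2.0-fold lower number from compound 1 to compound 3 (0.30 log units; within the scatter), so this pair is not separated, and the ring oxygen and hydrogen-bond acceptor that enter with morpholin-4-yl bring no readable difference from pyrrolidin-1-yl. Among these three compounds, compound 2 therefore stands alone as the most potent, while compounds 1 and 3 remain together, and nothing at hand explains this grouping.

The compounds shown leave open whether the standing of compound 2 belongs to open-chain amines more generally, as diethylamino or dimethylamino on the same carbon would test, or to diisopropylamino alone. They also leave open whether piperidin-1-yl, a six-membered ring without the oxygen, or 4-methylpiperazin-1-yl, with a second ring nitrogen, would stay with compounds 1 and 3 or move towards compound 2.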